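One Ring Swap on the Sulfur Side Chain

The source may hold more compounds than are shown below. What is called first, only, known or untested is meant among the compounds shown, and "the series" means these compounds.

Compound 1 `COc1ccc(CSc2nnc([C@@H](C)c3ccc4cc(OC)ccc4c3)n2-c2ccc(Cl)cc2)cc1` has been tested in a functional assay on DU-145 cells (Homo sapiens) for cytotoxicity, read by MTT assay (on this read-out higher numbers stand for weaker inhibition and lower numbers for stronger inhibition), where compound 1 gives 72600 nM. Within the data shown here, this is the only number available, so compound 1 cannot yet be ranked against anything. A relative, compound 2 `COc1ccc2cc([C@H](C)c3n[nH]c(=S)n3-c3cccc(Cl)c3)ccc2c1`, offers no help, since the entry for compound 2 reads "not determined" (no result reported).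

Still unmeasured is compound 3 `COc1ccc2cc([C@H](C)c3nnc(SCc4c(Cl)cccc4Cl)n3-c3ccc(Cl)cc3)ccc2c1`, which differs from compound 1 in one side group. The change is 2,6-dichlorophenyl in place of 4-methoxyphenyl on a saturated chain carbon bound to a sulfur. Seen one bond further out, 4-methoxybenzyl gives way to 2,6-dichlorobenzyl.

Among the measured compounds shown here, no measured pair shows what such a swap does in this assay, so the data give no basis for choosing a direction. No shift beyond the usual scatter of repeat measurements is expected, and the forecast rests on compound 1 alone, with its 72600 nM. The estimated step, a 1.5-fold lower number from compound 1 to compound 3 (0.16 log units; within the scatter), is correspondingly small. For compound 3 the expected value is 50000 nM, with an estimated range from 15000 nM to 130000 nM.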

Compound 3, half-maximal inhibitory concentration: 36100 nM
Beside the measured number, compound 3's estimate is 1.4-fold (0.14 log units) above it, and the stated range covers the measured number.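

In this assay, placing 2,6-dichlorophenyl where 4-methoxyphenyl stood on a saturated chain carbon bound to a sulfur gives a 2.0-fold lower number from compound 1 to compound 3 (0.30 log units; within the scatter), so this first measured pair at the position cannot be told apart in this read-out. The two groups have the same number of heavy atoms and the same kind of aromatic ring, but the swap trades the oxygen of the methoxy group, the hydrogen-bond acceptor of 4-methoxyphenyl, for two chlorines, and in this pair that exchange leaves the result within the normal spread of repeat measurements. No measurement available here offers an explanation for this outcome.

A single pair cannot show whether this position tolerates change in general, since both of its groups are uncharged benzyl-type side chains. An amine or a carboxylic acid on the ring, or a longer chain between the sulfur and the ring, might still shift the number well beyond the scatter, and the compounds shown cannot say whether it would.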